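The source may report more compounds than this note shows. Statements on the series, on what has been measured and on what is new or still open speak of the compounds shown alone.

In a functional assay on HCT-116 cells (Homo sapiens) for inhibition, read by sulforhodamine B assay, with a stated time of 48 h (on this read-out higher numbers stand for weaker inhibition of growth and lower numbers for stronger inhibition of growth), compound 2 (`CC(C)c1cc(C(=O)N(C)c2ccc(NC(=O)CCCCCCCCC(=O)NO)cc2)c(O)cc1O`) gives 590 nM and compound 3 (`CC(C)c1cc(C(=O)N(C)c2cccc(NC(=O)CCCCCCC(=O)NO)c2)c(O)cc1O`) gives 1170 nM as values within the scatter of each other, while compound 1 (`CCN(C(=O)c1cc(C(C)C)c(O)cc1O)c1ccc(NC(=O)CCCCCCC(=O)NO)cc1`) gives 3560 nM as a higher number, beyond the scatter from compound 2. Compound 4 (`CC(C)c1cc(C(=O)N(C)c2ccc(NC(=O)CCCCCC(=O)NO)cc2)c(O)cc1O`) departs from compound 2 by a single change (hydroxycarbamoyl in place of 3-(hydroxycarbamoyl)propyl on a saturated chain carbon, five bonds along the chain from a carbonyl carbon) on a saturated chain carbon, five bonds along the chain from a carbonyl carbon, leaving a shorter chain. For the measured compounds named here, no measured pair isolates this change, so only a small move toward a higher number is expected in this assay and perhaps none beyond the scatter. The expected step is a 1.5-fold higher number from compound 2 to compound 4 (0.18 log units; within the scatter) on this estimate. Compound 4 is estimated near 900 nM with an expected range from 300 nM to 3000 nM in all.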

Compound 4, concentration for 50% growth inhibition: 3780 nM
Compound 4: the middle estimate sits 4.2-fold (0.62 log units) below what was measured; the whole stated range lies below it.
By their numbers in this assay, from the lowest: compounds 2 and 3 (each within the scatter of the next); then compounds 1 and 4 (each within the scatter of the next).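

In this assay, for the compounds shown here, the change from 3-(hydroxycarbamoyl)propyl to hydroxycarbamoyl gives a 6.4-fold higher number from compound 2 to compound 4 (0.81 log units; beyond the scatter) and provides the first single-change comparison at this position. It shows that, between these two compounds, the shorter chain goes with weaker inhibition of growth, by a step beyond the scatter. No available evidence accounts for this step. The compounds shown leave open whether a longer chain than that of compound 2 would lower the number further. They also leave open whether shortening would have a similar effect with a carboxylic acid in place of the hydroxycarbamoyl end.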